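The source may report more compounds than this note shows. Statements on the series, on what has been measured and on what is new or still open speak of the compounds shown alone.

Within the data shown here, in a functional assay on A2780 cells (Homo sapiens) for antiproliferative activity, read by CellTiter-Glo, with a stated time of 72 h (a lower number here means a stronger inhibitor, a higher number a weaker inhibitor), compound 3 `C[C@@H](c1ccc(NC(=O)N2CC(c3cccnc3)C2)cc1)N1Cc2ccccc2C1=O` gives 1.5 nM and so sits in the middle of the three numbers known so far. Compound 2 `O=C(Nc1ccc(CN2Cc3ccccc3C2=O)cc1)N1CC(c2cccnc2)C1` stands lower at 0.6 nM and compound 1 `O=C(Nc1ccc(CN2C(=O)c3ccccc3C2=O)cc1)[C@H]1C[C@@H]1c1cccnc1` stands higher at 27 nM on the same measure.

The next molecule is compound 4 `C[C@H](NC(=O)c1ncccn1)c1ccc(NC(=O)N2CC(c3cccnc3)C2)cc1`, which keeps the rest of compound 3 and differs by one exchange: a group of 9 heavy atoms (5 carbon, 3 nitrogen, 1 oxygen; one six-membered aromatic ring with 2 hetero atoms) in place of a group of 10 heavy atoms (8 carbon, 1 nitrogen, 1 oxygen; one five-membered non-aromatic ring with 1 hetero atom, one six-membered aromatic ring of carbon only), on a saturated chain carbon bound to an aromatic carbon and a saturated chain carbon is the whole change. The group that enters is ((pyrimidin-2-yl)carbonyl)amino.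

Among the measured compounds shown here, only one measured step bears on this, and only loosely. Putting methyl in place of hydrogen on a chain carbon that carries the leaving group gave a 2.5-fold higher number from compound 2 to compound 3 (0.40 log units; beyond the scatter) and so moved the number only modestly. For the measured compounds named here, that step says nothing direct about exchanging the group itself, and no measured compound carries the pyrimidine ring. The expectation is therefore a modest move toward a weaker inhibitor, held with a wide margin. The expected size is a 2.7-fold higher number from compound 3 to compound 4 (0.43 log units; beyond the scatter) and this remains an estimate. For compound 4 the estimated value is 4 nM with an expected range from 1 nM to 16 nM as the likely span.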

Compound 4, half-maximal inhibitory concentration: 36 nM
For compound 4 the middle estimate is 9.0-fold (0.95 log units) below the measured one; the whole stated range lies below it.
By their numbers in this assay, from the lowest: compound 2; then compound 3; then compounds 1 and 4 (each within the scatter of the next).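

In this assay the saturated chain carbon bound to an aromatic carbon and a saturated chain carbon proves highly sensitive to which group it carries: exchanging the leaving group for ((pyrimidin-2-yl)carbonyl)amino gives a 24-fold higher number from compound 3 to compound 4 (1.38 log units; beyond the scatter) and so moves the number far more than the modest 2.5-fold higher number from compound 2 to compound 3 (0.40 log units; beyond the scatter) seen on adding methyl at this carbon. The earlier compounds shown here showed only that this carbon accepts a small addition with a modest shift, whereas this step shows that replacing the group on it can turn a low-nanomolar inhibitor into a much weaker one. The exchange alters the ring, adds a hydrogen-bond donor and changes the count of hydrogen-bond acceptors all at once, and no measurement here accounts for the weaker result.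

As far as these compounds go, it remains open whether the pyrimidine ring or the carbonylamino link matters more, and a benzoylamino group, with a ring of carbon only, would help separate the two. A plain amine on the same carbon would show how much of the group this position needs at all.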